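The source may report more compounds than this note shows. Statements on the series, on what has been measured and on what is new or still open speak of the compounds shown alone.

Of the compounds shown here, three from one series of diterpenoid-derived structures have been tested in a functional assay on MCF7 cells (Homo sapiens) for cytotoxicity, read by MTT assay, with a stated time of 48 h; a lower number here means a stronger inhibitor, a higher number a weaker inhibitor. Among the compounds with values here, compound 1 `C=CC(=C)CC[C@@H]1[C@@]2(C)CCC[C@](C)(COC(=O)/C=C\c3ccc(O)cc3)[C@@H]2CC[C@@]1(C)O` gives 15100 nM in this assay, and that is the only definite number among the three. Compound 2 `C=C1CC[C@@H]2[C@](C)(CCC[C@]2(C)C(=O)O)[C@H]1CC/C(C)=C/CO` reaches only a limit of the assay, reported as > 40000 nM in this assay. Compound 3 `C=C[C@@](C)(O)CC[C@H]1C(=C)CC[C@@H]2[C@]1(C)CCC[C@]2(C)C(=O)O` likewise stops at a limit, reported as > 40000 nM in this assay. The step that the two limits leave unreadable from compound 2 to compound 3 cannot be sized, because the limit of > 40000 nM in this assay, at which 2 of the 3 values shown sit, covers both of its ends.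

Compound 4 `C=CC(=C)CC[C@@H]1[C@@]2(C)CCC[C@](C)(COC(=O)/C=C\c3ccc(O)c(OC)c3)[C@@H]2CC[C@@]1(C)O` has not yet been measured. It differs from compound 1 in a single place: methoxy in place of hydrogen on an aromatic carbon. Within the data shown here, none of the measured steps touches the aromatic ring; the one step that has been measured changes a chain on the core, and even that step is unreadable. There is therefore no measured evidence pointing either way for this change, and the expectation rests on compound 1 alone, with its value of 15100 nM in this assay. Compound 4 is expected to give about 15000 nM in this assay, somewhere between 5000 nM and 45000 nM. The estimated change a 1.0-fold lower number from compound 1 to compound 4 (0.00 log units; within the scatter) is thus expected to stay within the usual scatter.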

Compound 4, half-maximal inhibitory concentration: 15400 nM
Estimate against measurement, compound 4: 1.0-fold (0.01 log units) below; measured number inside the range.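

Methoxy in place of hydrogen on an aromatic carbon, ortho to a hydroxy group and meta to a large group, is the only measured step here that touches the aromatic ring, and in this assay it reads a 1.0-fold higher number from compound 1 to compound 4 (0.01 log units; within the scatter) and so gives no readable difference. This shows that the aromatic ring of compound 1 can carry a methoxy group at this position, with the hydroxy group still in place, and keep its cytotoxic reading in this test, something compounds 2 and 3 could not show, as neither carries that ring. Nothing measured in the compounds shown explains why this change makes no readable difference.

On these data alone, whether the same aromatic carbon would accept other groups remains open: an amine, a carboxylic acid or a longer chain such as ethoxy could give a quite different reading, and a single methoxy result cannot speak for them. As far as these compounds go, it is also open what would happen if the hydroxy group itself gave way to a methoxy group or an amine, leaving the ring without that hydroxy group.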